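Swapping the Chain Terminus of Compound 1

This account rests on a few compounds, and the source may have more. Where it says the series, first, only, none or still open, it means among the compounds named here.

Compound 1 `N#CNC(=N)NCCCCCn1nc(-c2ccccc2)ccc1=O` was tested in a functional assay on the whole organism (stomach) with Rattus norvegicus as the target; on this read-out higher numbers stand for an effect only at larger amounts of compound and lower numbers for an effect already at smaller amounts. In this assay compound 1 gives only a limit, > 100 mg/kg, not a number. Compound 2 `C/N=C(/NC#N)NCCCCn1nc(Nc2ccccc2)ccc1=O` likewise gives only a limit in this assay, > 100 mg/kg. Going by the values given here, the single number comes from compound 3 `NC(=O)SCCCCCN1NC=CC=C1c1ccccc1`, which in this assay gives 23.8 mg/kg. Compound 1 therefore stands at the limit of > 100 mg/kg in this assay, at which 2 of the 3 values shown sit. Compound 4 `CC/N=C(\S)NCCCCn1nc(-c2ccccc2)ccc1=O` differs from compound 1 by a group of 6 heavy atoms (3 carbon, 2 nitrogen, 1 sulfur; no ring) in place of a group of 7 heavy atoms (3 carbon, 4 nitrogen; no ring), on a saturated chain carbon, four bonds along the chain from an aromatic nitrogen. Among the compounds with values here, no measured pair differs in only this place, so the size of this step is untested, and the two other compounds show only their own values. Compound 4 is expected to shift toward smaller amounts, by an at least 2.0-fold lower number from compound 1 to compound 4 (0.30 log units; that floor lies within the scatter), giving an estimate of 50 mg/kg with a range from 15 mg/kg to 150 mg/kg, though a limit remains a real possibility.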

Compound 4, dose for half-maximal effect: 37.2 mg/kg
Estimate against measurement, compound 4: 1.3-fold (0.13 log units) above; low and high end bracket the measured number.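

In this assay, the group of 6 heavy atoms (3 carbon, 2 nitrogen, 1 sulfur; no ring) in place of the group of 7 heavy atoms (3 carbon, 4 nitrogen; no ring) gives an at least 2.6-fold lower number from compound 1 to compound 4 (0.42 log units; beyond the scatter). This shows that the read-out responds to a change at this place, on a saturated chain carbon, four bonds along the chain from an aromatic nitrogen. The true size of the step stays unknown, since compound 1 gives only a limit, and such limits recur here: the limit of > 100 mg/kg in this assay, at which 2 of the 4 values shown sit.

The compounds shown leave open how an amine or a carboxylic acid at this place would read. They also leave open how far a longer chain would move the number.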